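A carbamoyl swap at the limit of the assay

This account rests on a few compounds, and the source may have more. Where it says the series, first, only, none or still open, it means among the compounds named here.

Compound 1 `C#CC(C)OC(=O)c1ccc(C(CC)(CC)c2ccc(OCCC(O)(CC)CC)c(C)c2)n1CC` and compound 2 `C#CCCOC(=O)c1ccc(C(CC)(CC)c2ccc(OCCC(O)(CC)CC)c(C)c2)n1CC` share one core and differ only in the alkynyl group on the ester oxygen. In a functional assay on PC-3 cells (Homo sapiens) for antiproliferative activity, read by MTT assay, with a stated time of 48 h (on this read-out higher numbers stand for weaker inhibition and lower numbers for stronger inhibition), compound 1 gives 14800 nM. Compound 2 gives > 50000 nM, which is a limit of the assay and not a number. Its standing rests only on (the limit of > 50000 nM in this assay, at which 1 of the 2 values shown sits).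

Compound 3 `CCOC(=O)CN(C)C(=O)c1ccc(C(CC)(CC)c2ccc(OCCC(O)(CC)CC)c(C)c2)n1CC` changes the same side of the molecule: ((ethoxycarbonyl)methyl)(methyl)amino in place of (but-3-yn-1-yl)oxy on a carbonyl carbon. For the measured compounds named here, one measured step bears on this site, an at least 3.3-fold higher number from compound 1 to compound 2 (0.52 log units; beyond the scatter). That step lies beyond the scatter, so this assay does respond to changes on this side, but it involved no swap of this kind and gives only a loose guide. A modest move towards a lower number is therefore expected, with the real chance that compound 3 also reads as a limit. The expected change is an at least 1.6-fold lower number from compound 2 to compound 3 (0.22 log units; that floor lies within the scatter). Compound 3 is estimated at 30000 nM, within an expected range of 10000 nM to 50000 nM.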

Compound 3, half-maximal inhibitory concentration: 7140 nM
The estimate for compound 3 lay 4.2-fold (0.62 log units) above the measured number; measured number below the stated range.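

In this assay, placing ((ethoxycarbonyl)methyl)(methyl)amino on the carbonyl carbon in place of (but-3-yn-1-yl)oxy gives an at least 7.0-fold lower number from compound 2 to compound 3 (0.84 log units; beyond the scatter), so this position also tolerates a change from an alkynyl ester to a substituted carbamoyl group, and the number falls rather than rises. The same group also compares favourably with the branched alkynyl ester, with a 2.1-fold lower number from compound 1 to compound 3 (0.32 log units; beyond the scatter); among these three compounds, compound 3 therefore has the lowest number, although that claim rests on one carbamoyl example. The larger of these two steps gives only a floor for the size of the change, and the entry for compound 2 is a limit of the assay and not a number: the limit of > 50000 nM in this assay, at which 1 of the 3 values shown sits.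

The compounds shown leave open whether the lower number goes with the amide nitrogen, its methyl group or the ethoxycarbonyl end of the new chain. A plain dimethylamino group on the same carbonyl carbon, or a carboxylic acid in place of the ethyl ester, would help to separate these parts.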